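A few compounds are considered here, and "the series" means these few. Any claim that something is new, unique, unknown or untested is made for them only; others in the source may bear on it.

Compound 1 `O=C(OC1CCC(CN2CCN(c3cc(=O)c4cc(C(F)(F)F)cc([N+](=O)[O-])c4s3)CC2)CC1)c1cccc(C(F)(F)F)c1` carries the shared core of this pair. In an ADME assay on Vero cells (Chlorocebus sabaeus) for cytotoxicity, read by MTT assay, with a stated time of 48 h (a lower number here means a stronger inhibitor, a higher number a weaker inhibitor), compound 1 gives only a limit, > 64 ug/mL. Compound 2 `C=CC(=O)OC1CCC(CN2CCN(c3cc(=O)c4cc(C(F)(F)F)cc([N+](=O)[O-])c4s3)CC2)CC1` differs from it by vinyl in place of 3-(trifluoromethyl)phenyl on a carbonyl carbon. In this assay compound 2 likewise gives only a limit, > 64 ug/mL. The step that the two limits leave unreadable from compound 1 to compound 2 cannot be read, because both values sit at the limit of > 64 ug/mL in this assay, at which 2 of the 2 values shown sit. Among the measured compounds shown here, compound 2 thus stands at the limit of this assay with no number of its own, and the one other value shown is the same limit.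

Compound 3 `O=c1cc(N2CCN(CC3CCC(OS(=O)(=O)c4ccccc4)CC3)CC2)sc2c([N+](=O)[O-])cc(C(F)(F)F)cc12` is not yet measured. It differs from compound 2 as phenylsulfonyl in place of vinylcarbonyl on an oxygen on a saturated carbon. For the measured compounds named here, the single measured step does not bear on this change in any readable way, so there is no measured guide to the size of a move from a vinylcarbonyl to a phenylsulfonyl here. Compound 3 is expected to show no step beyond the scatter in this assay, a number no higher from compound 2 to compound 3 (the limit leaves the size open), because compound 2 itself sits at the limit of > 64 ug/mL in this assay, at which 2 of the 2 values shown sit. Compound 3 is therefore estimated at 64 ug/mL, between 35 ug/mL and 120 ug/mL, most likely again reported only as a limit.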

Compound 3, half-maximal inhibitory concentration: > 64 ug/mL
Compound 3 was reported as a limit (the forecaster's own chance of this, stated with the estimate: 75%); the middle value sits exactly at the limit.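

No step can be read among compound 1, compound 2 and compound 3 in this assay, because each result is a limit and not a number: the limit of > 64 ug/mL in this assay, at which 3 of the 3 values shown sit.

The compounds shown leave open whether vinylcarbonyl, phenylsulfonyl and (3-(trifluoromethyl)phenyl)carbonyl on the oxygen differ at all in this assay.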